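Indole for furan: a cytotoxicity step still unreadable

The compounds below may be only part of what the source reports. "The series", "measured", "known", "first", "only" and "open" are said of these compounds alone.

Measured so far in an ADME assay on BJ cells (Homo sapiens) for cytotoxicity, read by CellTiter-Glo and resazurin assay, with a stated time of 72 h; on this read-out higher numbers stand for an effect only at larger amounts of compound and lower numbers for an effect already at smaller amounts:
Compound 1 `CC(C)N(Cc1cccc(OCCCCCC(=O)O)c1)C(=O)c1ccc(-c2ccco2)cc1` gives > 26000 nM, a limit of the assay rather than a number.
Compound 2 `CC(C)N(Cc1cccc(OCCCCCC(=O)O)c1)C(=O)c1ccc(-c2cccc(Oc3ccccc3)c2)cc1` gives > 18700 nM, again a limit.
Compound 3 `Cc1nnc(-c2cccc(-c3ccc(C(=O)N(Cc4cccc(OCCCCCC(=O)O)c4)C(C)C)cc3)c2)o1` gives > 26000 nM, again a limit.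

Compound 1 thus has no exact position; it sits at the limit of > 26000 nM in this assay, at which 2 of the 3 values shown sit, while the remaining value sits at the limit of > 18700 nM in this assay, at which 1 of the 3 values shown sits. For the measured compounds named here, two measured steps touch this set: a step that the two limits leave unreadable from compound 1 to compound 3 and a step that the two limits leave unreadable from compound 2 to compound 3. Going by the values given here, neither can be read, since both ends are limits, so no measured step gives a size or direction to lean on.

The new compound 4 `CC(C)N(Cc1cccc(OCCCCCC(=O)O)c1)C(=O)c1ccc(-c2ccc3cc[nH]c3c2)cc1` differs from compound 1 by 1H-indol-6-yl in place of furan-2-yl on an aromatic carbon. Nothing measured here shows that exchanging one group at this place moves the read-out out of the unreadable region; every compound with a different group there stayed at a limit. The step from compound 1 to compound 4 is therefore expected to be a step that the limit leaves unreadable from compound 1 to compound 4, meaning no step beyond the scatter, with the most likely outcome another limit. Compound 4 is accordingly estimated at 30000 nM, in a range from 15000 nM to 60000 nM.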

Compound 4, half-maximal effective concentration: > 26000 nM
Compound 4: no number, only a limit; the forecaster's own chance of this, stated with the estimate: 85%; the middle value lies beyond the limit too.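

In this assay compound 4 gives > 26000 nM, which is a limit of the assay and not a number. The steps to compound 4 from compound 1 and from compound 3 therefore cannot be read. The compounds shown leave open whether any group at this place would give a measurable value in this assay.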